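A few compounds are considered here, and "the series" means these few. Any claim that something is new, unique, unknown or untested is made for them only; others in the source may bear on it.

Measured compounds:
compound 1, `O=c1ccc(-c2ccc3cn[nH]c3c2)cn1Cc1cccc(C(F)(F)F)c1`: 32 nM
compound 2, `O=c1ccc(-c2ccc3cn[nH]c3c2)cn1Cc1ccccc1`: 75 nM
compound 3, `Nc1n[nH]c2cc(-c3ccc(=O)n(Cc4cccc(C(F)(F)F)c4)c3)ccc12`: 21 nM

All three were characterised in an assay for inhibition of MAP kinase-interacting serine/threonine-protein kinase 2 (Homo sapiens), read by luminescence and ADP-Glo, with a stated time of 2 h; a higher number here means a weaker inhibitor, a lower number a stronger inhibitor. Compound 1 and compound 2 share a core and differ in one place: hydrogen in place of trifluoromethyl on an aromatic carbon. This change gave a 2.3-fold higher number from compound 1 to compound 2 (0.37 log units; beyond the scatter), so removing the trifluoromethyl made the inhibitor somewhat weaker.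

Compound 3 differs from compound 1 in the core: amino in place of hydrogen on an aromatic carbon. The step of a 1.5-fold lower number from compound 1 to compound 3 (0.18 log units; within the scatter) lies within the usual scatter, so compound 3 and compound 1 cannot be separated on these numbers, although compound 3 does stand further from compound 2.

Compound 4, `Nc1n[nH]c2cc(-c3ccc(=O)n(Cc4ccccc4)c3)ccc12`, has not yet been measured in this assay . Among the compounds with values here, it is related to compound 3 by hydrogen in place of trifluoromethyl on an aromatic carbon, which is the same change as the one between compound 1 and compound 2, made on the same kind of place, on a core that carries the amino group.

Given that the one measured example of this change, from compound 1 to compound 2, gave a 2.3-fold higher number from compound 1 to compound 2 (0.37 log units; beyond the scatter), compound 4 is expected to show a step of similar size, a 2.3-fold higher number from compound 3 to compound 4 (0.36 log units; beyond the scatter), in this assay . On that basis compound 4 is estimated at 48 nM in this assay , with a plausible range from 22 nM to 105 nM.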

Compound 4, half-maximal inhibitory concentration: 32 nM
Estimate against measurement, compound 4: 1.5-fold (0.18 log units) above, within the range that was stated.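

In this assay, within the data shown here, the loss of trifluoromethyl on the core that carries the amino group gave a 1.5-fold higher number from compound 3 to compound 4 (0.18 log units; within the scatter), a step that does not separate the two compounds, yet it does not differ from the step seen on the core without the amino group: the same change on two cores in this assay, a 2.3-fold higher number (0.37 log units; beyond the scatter) from compound 1 to compound 2 and a 1.5-fold higher number (0.18 log units; within the scatter) from compound 3 to compound 4, 1.5-fold (0.19 log units) apart, within the scatter of two such steps The amino group, read on the core without trifluoromethyl, gave a 2.3-fold lower number from compound 2 to compound 4 (0.37 log units; beyond the scatter), and this step also agrees with its counterpart on the core that keeps trifluoromethyl: the same change on two cores in this assay, a 1.5-fold lower number (0.18 log units; within the scatter) from compound 1 to compound 3 and a 2.3-fold lower number (0.37 log units; beyond the scatter) from compound 2 to compound 4, 1.5-fold (0.19 log units) apart, within the scatter of two such steps Within these four compounds, each change therefore carried from one core to the other without a detectable difference in size, but that rests on only two pairs of steps, each pair including one step within the scatter, so it neither fixes a common size for either change nor establishes a rule for other cores.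

The compounds shown leave open whether a nitrile, a methoxy group or a chlorine atom on the same aromatic carbon would behave as trifluoromethyl does, and whether the amino group could be replaced by a methyl group or a longer amine. They also leave open whether the two changes would carry over in the same way on a core that differs further from these.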